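A nitro swap in a series stuck at the limit

This account rests on a few compounds, and the source may have more. Where it says the series, first, only, none or still open, it means among the compounds named here.

Measured so far in a functional assay on A549 cells (Homo sapiens) for inhibition, read by MTT assay, with a stated time of 72 h; on this read-out lower numbers stand for stronger inhibition and higher numbers for weaker inhibition (each value is a limit, not a number):
compound 1 `O=C(NO)c1ccc(CNCc2nc(-c3ccccc3)no2)cc1` gives > 100000 nM
compound 2 `O=C(NO)c1ccc(CNCc2nc(-c3ccc(C(F)(F)F)cc3)no2)cc1` gives > 100000 nM
compound 3 `O=C(NO)c1ccc(CNCc2nc(-c3ccc(Cl)cc3)no2)cc1` gives > 100000 nM

Compound 3 gives > 100000 nM as its result, and this is a limit. The two other measured compounds end the same way, so the series offers no number by which to rank them.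

The next compound, compound 4 `O=C(NO)c1ccc(CNCc2nc(-c3ccc([N+](=O)[O-])cc3)no2)cc1`, keeps the shared core and changes one group. The change is nitro in place of chloro on an aromatic carbon, para to a large group, and it counts as nitro in place of chloro on an aromatic carbon in full.

Among the compounds with values here, three measured steps bear on this, all swaps of the group on that carbon. They read a step that the two limits leave unreadable from compound 1 to compound 2 and a step that the two limits leave unreadable from compound 1 to compound 3 and a step that the two limits leave unreadable from compound 2 to compound 3 with no size to carry over. No direction and no step beyond the scatter is expected in this assay because the limit of > 100000 nM in this assay, at which 3 of the 3 values shown sit, is all the series shows so far. The estimated step is a number no higher from compound 3 to compound 4 (the limit leaves the size open) and it remains only an expectation. For compound 4 the expected value is 100000 nM with an estimated range from 40000 nM to 200000 nM and a further limit is the likeliest report.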

Compound 4, half-maximal inhibitory concentration: > 100000 nM
Compound 4 was reported as a limit; the forecaster's own chance of this, stated with the estimate: 85%; the middle value sits exactly at the limit.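

In this assay compound 4 gives > 100000 nM, which is a limit and not a number. Within the data shown here, no step to compound 4 from compound 1, compound 2 or compound 3 can be read. The compounds shown leave open how strongly each one inhibits and whether the group on that aromatic carbon matters at all, because all of them end at the same point: the limit of > 100000 nM in this assay, at which 4 of the 4 values shown sit.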